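Amide for Alkyne on a Benzylamine Scaffold

A few compounds are considered here, and "the series" means these few. Any claim that something is new, unique, unknown or untested is made for them only; others in the source may bear on it.

Compound 1 `N#CCN(Cc1ccc(I)cc1)Cc1ccc2ccccc2c1`: 0%
Compound 2 `N#CCN(Cc1ccc(CCc2ccccc2)cc1)Cc1ccc2ccccc2c1`: 20%
Compound 3 `C#CCN(Cc1ccccc1)Cc1ccc2ccccc2c1`: 0%

Of the compounds shown here, three have been measured in an assay on HEK293 cells for binding affinity to Substance-K receptor (Rattus norvegicus), read by FRET, tested at 10 uM; a higher number here means more inhibition at the concentration tested (going by the name of the read-out), a lower number less inhibition. For the measured compounds named here, compound 1 gives 0%, and compound 2 gives 20%; the only single-point step between measured compounds is a number 20 percentage points higher from compound 1 to compound 2 (beyond the scatter). Compound 3 gives 0%, level with compound 1 at the digits shown and, together with it, the lowest of the three numbers; compound 2 sits higher by a step beyond the scatter. Compound 3 and compound 1 differ in more than one place, so their equal values alone do not tell what either change does.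

Compound 4 `CN1CCN(C(=O)CN(Cc2ccccc2)Cc2ccc3ccccc3c2)CC1` is not yet measured. It differs from compound 3 in this way: (4-methylpiperazin-1-yl)carbonyl in place of ethynyl on a saturated chain carbon bound to an amine nitrogen. Going by the values given here, no measured step touches the saturated chain carbon bound to the amine nitrogen; the one known step, a number 20 percentage points higher from compound 1 to compound 2 (beyond the scatter), concerns an aromatic carbon and does not bear on this change. With nothing to build on, the expectation for compound 4 is a step of a number 10 percentage points higher from compound 3 to compound 4 (within the scatter), that is, little or no change beyond the scatter, with the low floor of compound 3 leaving room only upward. Compound 4 is therefore estimated at 10%, within 0% to 35%.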

Compound 4, a percentage reported as inhibition, at one concentration (the size of the read-out at that concentration, not a potency): 0%
For compound 4 the middle estimate is 10 percentage points above the measured one; low and high end bracket the measured number.
By their numbers in this assay, from the lowest: compounds 1, 3 and 4 (each within the scatter of the next); then compound 2.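

In this assay, for the compounds shown here, putting (4-methylpiperazin-1-yl)carbonyl in place of ethynyl on a saturated chain carbon bound to an amine nitrogen gives no change at the digits printed from compound 3 to compound 4 (within the scatter), and this is the first step read at this place. A group of 9 heavy atoms, with a six-membered non-aromatic ring and 2 hydrogen-bond acceptors, thus leaves the number where the 2 heavy atoms of ethynyl had it, but compound 4 stands at 0%, so this single concentration cannot tell whether the two groups are truly alike here or whether both merely fall short of a level the read-out can show. No evidence at hand explains this result.

Going by these compounds alone, it remains open whether phenethyl on an aromatic carbon, the one change with a step beyond the scatter, a number 20 percentage points higher from compound 1 to compound 2 (beyond the scatter), would raise the number in a compound that also carries (4-methylpiperazin-1-yl)carbonyl. Also open, from the compounds shown here alone, is what a primary amide, a carboxylic acid or a longer chain would give on the saturated chain carbon bound to the amine nitrogen.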